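Chloro for methyl: the step from compound 3 to compound 4

The source may report more compounds than this note shows. Statements on the series, on what has been measured and on what is new or still open speak of the compounds shown alone.

The series keeps the core of compound 1 `COc1ccc(CNC(=O)/C(C#N)=C/c2ccc[nH]2)cc1` and varies the ring on the double-bonded chain carbon. In a functional assay on MIA cells (Homo sapiens) for inhibition, read by MTT assay, with a stated time of 72 h (a higher number here means a weaker inhibitor of growth, a lower number a stronger inhibitor of growth), compound 1 gives > 50000 nM, which is a limit of the assay and not a number (the limit of > 50000 nM in this assay, at which 1 of the 3 values shown sits). Compound 2 `COc1ccc(CNC(=O)/C(C#N)=C/c2ccco2)cc1` gives 34000 nM in this assay. Compound 3 `COc1ccc(CNC(=O)/C(C#N)=C/c2ccc(C)o2)cc1` gives 51000 nM in this assay. Of the two numbers shown, compound 3 and compound 2 lie within the scatter of each other, so no order between them is claimed. The measured steps read as follows: an at least 1.4-fold lower number from compound 1 to compound 2 (0.16 log units; that floor lies within the scatter); a step that the limit leaves unreadable from compound 1 to compound 3; a 1.5-fold higher number from compound 2 to compound 3 (0.18 log units; within the scatter).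

Compound 4 `COc1ccc(CNC(=O)/C(C#N)=C/c2ccc(Cl)o2)cc1` differs from compound 3 in one place: chloro in place of methyl on an aromatic carbon. For the measured compounds named here, the only measured step at this ring carbon, a 1.5-fold higher number from compound 2 to compound 3 (0.18 log units; within the scatter), stayed within the scatter, and no measured step swaps one group for another at that carbon. The other two steps concern the ring itself and do not bear on this change. The expected step is therefore a 1.0-fold lower number from compound 3 to compound 4 (0.01 log units; within the scatter), nothing beyond the scatter. Compound 4 is expected to give 50000 nM in this assay, with a range from 20000 nM to 150000 nM.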

Compound 4, concentration for 50% growth inhibition: 15000 nM
Compound 4: middle estimate off by 3.3-fold (0.52 log units), on the high side; measured number below the stated range.
By their numbers in this assay, from the lowest: compound 4; then compounds 2 and 3 (each within the scatter of the next).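

Working from this assay, the ring carbon next to the ring oxygen now shows its first swap with a step beyond the scatter: a 3.4-fold lower number from compound 3 to compound 4 (0.53 log units; beyond the scatter). The hydrogen comparison points the same way, since chloro gives a 2.3-fold lower number from compound 2 to compound 4 (0.36 log units; beyond the scatter), while methyl at the same carbon gave a 1.5-fold higher number from compound 2 to compound 3 (0.18 log units; within the scatter), so among the three groups shown at this carbon, only chloro moves the number beyond the scatter. Against the 1H-pyrrol-2-yl ring, the 5-chlorofuran-2-yl ring gives an at least 3.3-fold lower number from compound 1 to compound 4 (0.52 log units; beyond the scatter), but this step is only a floor, and the value of compound 1 is a limit of the assay and not a number: the limit of > 50000 nM in this assay, at which 1 of the 4 values shown sits.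

Whether the step belongs to chloro alone or extends to bromo, trifluoromethyl or an amine at this carbon remains open, and the compounds shown give no cause for it. Also open, as far as these compounds go, is whether chloro would give a readable step on the 1H-pyrrol-2-yl ring of compound 1, or whether the step depends on the furan ring.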